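Replacing chloro with hydroxy in compound 2

This account rests on a few compounds, and the source may have more. Where it says the series, first, only, none or still open, it means among the compounds named here.

Compound 1 `COc1cccc(/C=C2\CCC/C(=C\c3ccc(Cl)cc3)C2=O)c1OC` gives 11100 nM
Compound 2 `COc1ccc(/C=C2\CCC/C(=C\c3cccc(Cl)c3)C2=O)cc1OC` gives 4900 nM

Going by the values given here, only two compounds have been measured so far, both in a functional assay on HT-1080 cells (Homo sapiens) for cytotoxicity, read by MTT assay, with a stated time of 72 h (on this read-out higher numbers stand for weaker inhibition and lower numbers for stronger inhibition), and both at micromolar-range numbers. Compound 2 gives 4900 nM and holds the lower of the two numbers, so it is the stronger inhibitor here. Compound 1 gives 11100 nM and the gap between them lies beyond the usual scatter. These two compounds differ in more than one place, so their gap cannot be tied to any single structural feature.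

The next compound is compound 3 `COc1ccc(/C=C2\CCC/C(=C\c3cccc(O)c3)C2=O)cc1OC`. It matches compound 2 except for one change, 3-chlorophenyl to 3-hydroxyphenyl, which puts hydroxy in place of chloro on an aromatic carbon, meta to a large group (hydroxy in place of chloro on an aromatic carbon).

Among the compounds with values here, no measured pair shows this swap, so the estimate starts from compound 2 (4900 nM). The expected step in this assay (a 1.0-fold higher number from compound 2 to compound 3 (0.01 log units; within the scatter)) is none beyond the scatter, with no direction favoured, though the wide range allows for a surprise either way. For compound 3 the estimated value is 5000 nM (expected range 1700 nM to 15000 nM).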

Compound 3, half-maximal inhibitory concentration: 1700 nM
Compound 3: the middle estimate sits 2.9-fold (0.47 log units) above what was measured, within the range that was stated.
By their numbers in this assay, from the lowest: compound 3; then compound 2; then compound 1.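

In this assay, the change from 3-chlorophenyl to 3-hydroxyphenyl gives a 2.9-fold lower number from compound 2 to compound 3 (0.46 log units; beyond the scatter). Going by these compounds alone, this is the first single change whose effect can be read on its own, as the gap between compound 1 and compound 2 could not be tied to any one feature. It shows that this position on the aromatic ring is sensitive to what sits there: exchanging one heavy atom, with the rest of the molecule held constant, moves the result modestly towards stronger inhibition, and the incoming hydroxy brings one hydrogen-bond donor and one hydrogen-bond acceptor that chloro lacks. No supporting measurement bears on why the number falls, so this single pair records the size of the change but not its cause.

Going by these compounds, it remains open whether the gain is particular to hydroxy or would also appear with another group on the same carbon, such as an amine or a methoxy. On these data alone, it is also open whether the same swap would give a similar step on the differently substituted framework of compound 1.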